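Swapping an aryl group for an alkoxy chain

This account rests on a few compounds, and the source may have more. Where it says the series, first, only, none or still open, it means among the compounds named here.

Of the compounds shown here, two have been measured in an assay on cell membranes for binding affinity to Neuronal acetylcholine receptor; alpha4/beta2 (Rattus norvegicus), read by radioligand binding; on this read-out higher numbers stand for weaker inhibition and lower numbers for stronger inhibition. Compound 1 `CCOc1cncc(N2CCNCC2)c1` carries an ethoxy group and a piperazine on its core; in this assay compound 1 gives 500 nM. Compound 2 `c1cncc(-c2cncc(N3CCCNCC3)c2)c1` carries a pyridin-3-yl group and a diazepane instead; in this assay compound 2 gives 2.8 nM, the lower of the two numbers, and the gap to compound 1 lies well beyond the scatter, so compound 2 is the stronger binder of the pair.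

Compound 3 `CC(C)COc1cncc(N2CCCNCC2)c1` is not yet measured. It keeps the core and diazepane of compound 2 and changes one group: isobutoxy in place of pyridin-3-yl on an aromatic carbon. Among the compounds with values here, the only other compound with an alkoxy group in that place, compound 1, gives 500 nM, though it also differs in its saturated ring, so no single-change step is available. The expectation is that this swap costs affinity, with a step from compound 2 to compound 3 of a 21-fold higher number from compound 2 to compound 3 (1.33 log units; beyond the scatter), beyond the scatter. Compound 3 is therefore estimated at 60 nM, within a range of 10 nM to 400 nM.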

Compound 3, half-maximal inhibitory concentration: 2.2 nM
Estimate against measurement, compound 3: 27-fold (1.44 log units) above; the whole stated range lies above it.
By their numbers in this assay, from the lowest: compounds 3 and 2 (each within the scatter of the next); then compound 1.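

With the diazepane and the shared core held fixed, swapping the ring for an open chain at this position leaves binding unchanged in this assay: replacing pyridin-3-yl with isobutoxy gives a 1.3-fold lower number from compound 2 to compound 3 (0.10 log units; within the scatter). An aromatic ring at this position is therefore not needed for binding in this pair, since isobutoxy has no ring and the two compounds still cannot be told apart. Compound 1 differs from compound 3 in two places, the ethoxy group and the piperazine, so its much higher number cannot be assigned to either difference, and nothing shown here explains why the two groups match.

A compound pairing the ethoxy group with the diazepane, or isobutoxy with the piperazine, would separate those two differences and show which one accounts for the number of compound 1. On these data alone, it also remains open how far this tolerance extends, for instance to a longer chain such as hexyloxy, to a plain phenyl ring, or to an amine at this position.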